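This account rests on a few compounds, and the source may have more. Where it says the series, first, only, none or still open, it means among the compounds named here.

Measured in an ADME assay on J774 cells (Mus musculus) for cytotoxicity; on this read-out higher numbers stand for an effect only at larger amounts of compound and lower numbers for an effect already at smaller amounts:
- compound 1 `CCCCc1cc2c(=O)c(CC)c[nH]c2cc1OCCOc1ccccc1`: 360 nM
- compound 2 `CCCCc1ccc2[nH]cc(C(=O)OC)c(=O)c2c1`: > 20000 nM (a limit of the assay, not a number)

Among the measured compounds shown here, compound 1 is the only measured compound with a numerical reading, 360 nM. Compound 2 gives only a limit, and it stands at the limit of > 20000 nM in this assay, at which 1 of the 2 values shown sits.

The next compound is compound 3 `COC(=O)c1c[nH]c2ccc(OC)cc2c1=O`, with methoxy in place of butyl on an aromatic carbon. For the measured compounds named here, no measured step between two compounds covers this change, so any forecast is tentative. The forecast starts from compound 2, whose > 20000 nM is a limit. In this assay, no shift beyond the scatter is expected, and the expected step that the limit leaves unreadable from compound 2 to compound 3 is small, with another limit reading the likeliest result. For compound 3 the estimated value is 25000 nM, with an expected range of 12000 nM to 50000 nM.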

Compound 3, half-maximal effective concentration: 6180 nM
For compound 3 the middle estimate is 4.0-fold (0.61 log units) above the measured one, outside the stated range (below it).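

In this assay, methoxy in place of butyl on this aromatic carbon gives an at least 3.2-fold lower number from compound 2 to compound 3 (0.51 log units; beyond the scatter). The position is therefore not silent on this read-out: with the rest of the structure unchanged, this one exchange leads to a numerical reading, with compound 3 at 6180 nM. The step gives only a minimum size, since one end of it is a limit of the assay rather than a number: the limit of > 20000 nM in this assay, at which 1 of the 3 values shown sits.

Butyl and methoxy differ in both heavy-atom count and the oxygen, so this pair cannot separate the two; an ethyl or a butoxy group at this carbon would begin to do so. Compound 1 differs from both compounds in more than one place, leaving its reading unconnected to this change.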